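A Larger Ring Group in Place of Dimethylamino

A few compounds are considered here, and "the series" means these few. Any claim that something is new, unique, unknown or untested is made for them only; others in the source may bear on it.

Within the data shown here, compound 1 `CC(C(=O)NCc1ccc(C(F)(F)F)nc1N(C)C)c1ccc(NS(C)(=O)=O)c(F)c1` is the only compound here with a measured number. In a functional assay on CHO-K1 cells for antagonist activity at transient receptor potential cation channel subfamily V member 1 (Homo sapiens), read by FLIPR (a lower number here means a stronger inhibitor, a higher number a weaker inhibitor), compound 1 gives 2390 nM. Among the measured compounds shown here, compound 2 `C[C@H](C(=O)NCc1ccc(C(F)(F)F)nc1N1CCC[C@H]1C(=O)N(C)C)c1ccc(NS(C)(=O)=O)c(F)c1` carries a different, larger group at the same place on the shared core; in this assay compound 2 gives "not active" (no number reported), with no number given, so no measured step connects the two compounds. Compound 3 `CCCCOC1CCN(c2nc(C(F)(F)F)ccc2CNC(=O)C(C)c2ccc(NS(C)(=O)=O)c(F)c2)CC1` differs from compound 1 in one place: a group of 11 heavy atoms (9 carbon, 1 nitrogen, 1 oxygen; one six-membered non-aromatic ring with 1 hetero atom) in place of a group of 3 heavy atoms (2 carbon, 1 nitrogen; no ring), on an aromatic carbon. For the measured compounds named here, no measured pair shows what such a change does, so the size of the step is uncertain. The step of a 2.4-fold lower number from compound 1 to compound 3 (0.38 log units; beyond the scatter) is expected, toward somewhat stronger inhibition, though it may not exceed the usual scatter. Because compound 1 stands at 2390 nM, compound 3 is expected in this assay to give about 1000 nM, with a range from 150 nM to 6000 nM.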

Compound 3, half-maximal inhibitory concentration: 28.2 nM
Estimate against measurement, compound 3: 35-fold (1.55 log units) above; the whole stated range lies above it.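

In this assay, the group of 11 heavy atoms in place of dimethylamino gives an 85-fold lower number from compound 1 to compound 3 (1.93 log units; beyond the scatter), so this place on the shared core can hold a much larger group, and here the larger group comes with far stronger inhibition. This rests on one pair: compound 2 also carries a larger group at this place but has no number, so its step cannot be read and size alone does not predict the result. Nothing measured here bears on why the number falls.

As far as these compounds go, it remains open which part of the entering group matters, the ring or the butoxy chain attached to it. A plain piperidine without that chain, or the same ring with a shorter methoxy group, would separate the two.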